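The compounds below may be only part of what the source reports. "The series", "measured", "known", "first", "only" and "open" are said of these compounds alone.

Measured so far:
Compound 1 `O=C1OC(c2ccncc2)CN1C1CCN(Cc2cc3ccccc3[nH]2)CC1`. In an in vitro functional assay on RBL cells for antagonist activity at C-C chemokine receptor type 8 (Homo sapiens), read by FLIPR and calcium flux (on this read-out lower numbers stand for stronger inhibition and higher numbers for weaker inhibition), compound 1 reaches only the limit < 50200 nM.
Compound 2 `COc1ccc2nccc(C3CN(C4CCN(Cc5cc6ccccc6o5)CC4)C(=O)O3)c2c1`. In this assay compound 2 gives 1260 nM.

Going by the values given here, compound 2 holds the only number in this assay; the other entry is the limit of < 50200 nM in this assay, at which 1 of the 2 values shown sits, so there is no measured step within the pair to rank against.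

The next compound, compound 3 `COc1ccc2nccc(C3CN(C4CCN(Cc5cccc(Cl)c5)CC4)C(=O)O3)c2c1`, differs from compound 2 in one place: 3-chlorophenyl in place of 1-benzofuran-2-yl on a saturated chain carbon bound to an amine nitrogen in a ring. Among the compounds with values here, no measured step speaks to this change. The expectation is a small loss in this assay from compound 2 to compound 3, around a 1.7-fold higher number from compound 2 to compound 3 (0.24 log units; within the scatter), close to the scatter of the method and open in direction. Compound 3 is estimated at 2200 nM, within 500 nM to 9000 nM.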

Compound 3, half-maximal inhibitory concentration: 6310 nM
Estimate against measurement, compound 3: 2.9-fold (0.46 log units) below; the measured number falls inside the stated range.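

In this assay, going by these compounds alone, the group on a saturated chain carbon bound to an amine nitrogen in a ring now has a measured effect: 3-chlorophenyl in place of 1-benzofuran-2-yl gives a 5.0-fold higher number from compound 2 to compound 3 (0.70 log units; beyond the scatter) and provides the first readable step. Of these two groups, 1-benzofuran-2-yl therefore gives the stronger inhibition on the shared core, although one pair establishes no wider pattern. Nothing at hand gives a cause for this step.

Still open, going by these compounds, is whether the step follows from losing the five-membered aromatic ring of 1-benzofuran-2-yl or from the entry of chlorine. Among the compounds shown, none carries a plain phenyl or a naphthalen-2-yl at this place, and either group would help separate those two readings.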